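Adding tert-butyl to the phenyl of compound 2

This account rests on a few compounds, and the source may have more. Where it says the series, first, only, none or still open, it means among the compounds named here.

Compound 2 `c1ccc(-c2csc(Nc3cccc4ccccc34)n2)cc1` stands as the higher of the two numbers measured in an assay on CCRF-CEM cells for displacement of a labelled ligand from C-C chemokine receptor type 4 (Homo sapiens); on this read-out lower numbers stand for stronger inhibition and higher numbers for weaker inhibition: in this assay compound 2 gives 5500 nM, whereas compound 1 `CC(C)(C)Cc1csc(Nc2cccc3ccccc23)n1` gives 220 nM. Among the measured compounds shown here, the single measured step, a 25-fold higher number from compound 1 to compound 2 (1.40 log units; beyond the scatter), replaced neopentyl by phenyl on an aromatic carbon. Compound 3 `CC(C)(C)c1ccc(-c2csc(Nc3cccc4ccccc34)n2)cc1` differs from compound 2 in one place: tert-butyl in place of hydrogen on an aromatic carbon, on an aromatic carbon of a six-membered aromatic ring of carbon only, para to a large group. For the measured compounds named here, no measured step adds a group to this ring, so the expectation rests on that one step alone. Because a 25-fold higher number from compound 1 to compound 2 (1.40 log units; beyond the scatter) was large, and neopentyl carries a tert-butyl, a partial return toward the number of compound 1 is expected when tert-butyl is added. The expected step is a 3.7-fold lower number from compound 2 to compound 3 (0.56 log units; beyond the scatter). For compound 3 the estimate in this assay is 1500 nM, with a range from 300 nM to 8000 nM.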

Compound 3, half-maximal inhibitory concentration: 900 nM
The estimate for compound 3 lay 1.7-fold (0.22 log units) above the measured number; the range from low to high includes it.
By their numbers in this assay, from the lowest: compound 1; then compound 3; then compound 2.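

Compound 3 shows that this ring carbon, para to a large group, can carry a substituent without a loss: in this assay adding tert-butyl gives a 6.1-fold lower number from compound 2 to compound 3 (0.79 log units; beyond the scatter), a modest step. The earlier step swapped one whole group for another, whereas this one keeps the phenyl and builds on it, so a lower number can be reached with the phenyl still in place. The data shown offer no measured explanation for this change.

As far as these compounds go, it remains open whether the lower number belongs to tert-butyl in particular, since a methyl, a methoxy, an amine or a carboxylic acid on the same carbon would show how much depends on the group. Also open, from the compounds shown here alone, is whether tert-butyl would give a similar step on another carbon of this ring.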